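A Benzyl Swap on an Inactive Scaffold

The source may report more compounds than this note shows. Statements on the series, on what has been measured and on what is new or still open speak of the compounds shown alone.

Measured compounds:
Compound 1, `O=c1ccoc2cc(OCc3cn(Cc4cccc(Br)c4)nn3)ccc12`: > 100000 nM
Compound 2, `O=c1ccoc2cc(OCc3cn(Cc4ccccc4Cl)nn3)ccc12`: > 100000 nM

In a functional assay on A549 cells (Homo sapiens) for cytotoxicity, read by MTT assay, with a stated time of 48 h (a lower number here means a stronger inhibitor, a higher number a weaker inhibitor), compound 1 gives > 100000 nM, which is a limit of the assay rather than a number. Compound 2 gives > 100000 nM in this assay, again a limit. Both shown values sit at that limit, so the step that the two limits leave unreadable from compound 1 to compound 2 cannot be read in either direction, and compound 2 stands only as a limit, with the one further value shown also being a limit.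

Compound 3, `N#Cc1cccc(Cn2cc(COc3ccc4c(=O)ccoc4c3)nn2)c1`, differs from compound 2 by 3-cyanophenyl in place of 2-chlorophenyl on a saturated chain carbon bound to an aromatic nitrogen. Among the compounds with values here, the only measured step that bears on this change is the one from compound 1 to compound 2, and it is unreadable because of the limit of > 100000 nM in this assay, at which 2 of the 2 values shown sit. Nothing in the two values therefore points to a direction or a size for the change on the saturated chain carbon bound to the aromatic nitrogen.

The step of a number no higher from compound 2 to compound 3 (the limit leaves the size open) is accordingly expected to be none beyond the scatter, with compound 3 most likely returning a limit as well. Compound 3 is estimated at 100000 nM in this assay, within a range from 30000 nM to 300000 nM.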

Compound 3, half-maximal inhibitory concentration: 14300 nM
The estimate for compound 3 lay 7.0-fold (0.84 log units) above the measured number; the measured number lies below the stated range.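

The place on the saturated chain carbon bound to an aromatic nitrogen, where the earlier pair left the step unreadable, now proves able to shift the read-out in this assay: 3-cyanophenyl in place of 2-chlorophenyl gives an at least 6.9-fold lower number from compound 2 to compound 3 (0.84 log units; beyond the scatter). Cyano in place of bromo on an aromatic carbon gives an at least 6.9-fold lower number from compound 1 to compound 3 (0.84 log units; beyond the scatter), so the nitrile-bearing compound separates from both earlier compounds while the shared core stays the same. Both steps give only a lower bound on the size of the change because each starts from a limit of the assay rather than a number: the limit of > 100000 nM in this assay, at which 2 of the 3 values shown sit.

The compounds shown leave open whether the nitrile itself is what matters, or whether another group on the benzyl ring, such as a methoxy, an amine or a carboxylic acid, would also bring a measurable number in this assay. They also leave open what a longer chain in place of the single carbon between the aromatic nitrogen and the 3-cyanophenyl ring would do to the value.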